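The source may hold more compounds than are shown below. What is called first, only, known or untested is meant among the compounds shown, and "the series" means these compounds.

Measured in a functional assay on SMMC-7721 cells (Homo sapiens) for antiproliferative activity, read by MTT assay, with a stated time of 48 h; a lower number here means a stronger inhibitor, a higher number a weaker inhibitor:
- Compound 1 `Cn1cc(C2=C(c3nn(CCCN4CCCCC4)c4ncccc34)C(=O)N(c3cccc4ccccc34)C2=O)c2ccccc21`: 220 nM
- Compound 2 `Cn1cc(C2=C(c3nn(CCCn4ccnc4)c4ncccc34)C(=O)NC2=O)c2ccccc21`: > 100000 nM

The entry for compound 2, > 100000 nM, is a limit of the assay and not a number. Compound 3 `Cn1cc(C2=C(c3nn(CCCN4CCCCC4)c4ncccc34)C(=O)NC2=O)c2ccccc21` has piperidin-1-yl in place of the 1H-imidazol-1-yl of compound 2, on a saturated chain carbon, three bonds along the chain from an aromatic nitrogen (piperidin-1-yl in place of 1H-imidazol-1-yl on a saturated chain carbon, three bonds along the chain from an aromatic nitrogen). Compound 1 also carries piperidin-1-yl and gives 220 nM, but it differs from compound 3 elsewhere, so only part of that strength is expected to carry over. The expected step of an at least 12-fold lower number from compound 2 to compound 3 (1.09 log units; beyond the scatter) is large, towards a stronger inhibitor and beyond the scatter. For compound 3 the estimated value is 8000 nM, with an expected range of 1500 nM to 50000 nM.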

Compound 3, half-maximal inhibitory concentration: 7670 nM
Beside the measured number, compound 3's estimate is 1.0-fold (0.02 log units) above it; the range from low to high includes it.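

On the propyl chain, piperidin-1-yl in place of 1H-imidazol-1-yl gives an at least 13-fold lower number from compound 2 to compound 3 (1.11 log units; beyond the scatter), so the ring at the end of the chain matters in this assay. Compound 2's entry is a limit of the assay and not a number, so the true step may be larger: the limit of > 100000 nM in this assay, at which 1 of the 3 values shown sits. Hydrogen in place of naphthalen-1-yl gives a 35-fold higher number from compound 1 to compound 3 (1.54 log units; beyond the scatter), so the group on the amide-type nitrogen in a ring also counts, separately from the chain end.

On these data alone, whether morpholin-4-yl or a dimethylamino group at the chain end would match piperidin-1-yl stays open. So does whether a phenyl or methyl group on that nitrogen would keep the strength naphthalen-1-yl gives.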